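Chloro for methoxymethyl: a first estimate for compound 3

The compounds below may be only part of what the source reports. "The series", "measured", "known", "first", "only" and "open" are said of these compounds alone.

Measured so far:
compound 1, `O=C(O)CCCSCCN1C(=O)OC[C@@H]1/C=C/[C@@H](O)Cc1cccc(C(F)(F)F)c1`: > 10000 nM
compound 2, `COCc1cccc(C[C@H](O)/C=C/[C@H]2COC(=O)N2CCSCCCC(=O)O)c1`: > 10000 nM

Working notes on the series. In an assay on CHO cells for displacement of a labelled ligand from prostaglandin E2 receptor EP2 subtype (Mus musculus), read by scintillation counting, with a stated time of 60 min (a lower number here means a stronger inhibitor, a higher number a weaker inhibitor), compound 1 gives > 10000 nM, a limit of the assay rather than a number. In this assay compound 2 gives > 10000 nM, again a limit and not a number. Within the data shown here, the only measured step, a step that the two limits leave unreadable from compound 1 to compound 2, is therefore unreadable in size and direction; both values sit at the limit of > 10000 nM in this assay, at which 2 of the 2 values shown sit. Compound 2 thus stands at the weak end of what the assay can report, with nothing to separate it from compound 1.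

Compound 3, `O=C(O)CCCSCCN1C(=O)OC[C@@H]1/C=C/[C@@H](O)Cc1cccc(Cl)c1`, differs from compound 2 by chloro in place of methoxymethyl on an aromatic carbon. Among the measured compounds shown here, no measured step bears on a chloro group in this place. For the measured compounds named here, what is known is only that compound 2 with its methoxymethyl group, and compound 1 with its trifluoromethyl group, both return the limit (the limit of > 10000 nM in this assay, at which 2 of the 2 values shown sit), so no anchor exists for a readable step in either direction. The expectation for compound 3 in this assay is therefore a value near the limit, estimated at 15000 nM with a range of 3000 nM to 60000 nM. The step that the limit leaves unreadable from compound 2 to compound 3 is expected to be no more than the scatter, and a further limit rather than a number is the likelier outcome.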

Compound 3, inhibition constant: > 10000 nM
Compound 3 gave a limit, no number; the forecaster's own chance of this, stated with the estimate: 75%; the middle value does not contradict the limit.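

Compound 3 returns a limit and not a number, so the steps from compound 2 to compound 3 and from compound 1 to compound 3 cannot be read in size or direction: the limit of > 10000 nM in this assay, at which 3 of the 3 values shown sit.

The compounds shown leave open whether any change, at this aromatic carbon or elsewhere on the shared core, gives a readable number in this assay at all.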